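This account rests on a few compounds, and the source may have more. Where it says the series, first, only, none or still open, it means among the compounds named here.

Measured in a functional assay on K562 cells (Homo sapiens) for inhibition, read by trypan blue exclusion, with a stated time of 72 h; a lower number here means a stronger inhibitor, a higher number a weaker inhibitor:
- compound 1 `Cn1c(=O)c(S(=O)(=O)c2ccc(F)cc2F)cc2cnc(Nc3ccc4sccc4c3)nc21`: 500 nM
- compound 2 `Cn1c(=O)c(C(=O)Nc2ccc(F)cc2)cc2cnc(Nc3ccc4[nH]ccc4c3)nc21`: 5000 nM

Compound 1 holds the lower of the two numbers, and the gap to compound 2 lies beyond the usual scatter. Compound 3 `Cn1c(=O)c(S(=O)(=O)c2ccc(F)cc2F)cc2cnc(Nc3ccc4c(c3)CC(=O)N4)nc21` keeps the core of compound 1 and changes one group: a group of 10 heavy atoms (8 carbon, 1 nitrogen, 1 oxygen; one five-membered non-aromatic ring with 1 hetero atom, one six-membered aromatic ring of carbon only) in place of a group of 9 heavy atoms (8 carbon, 1 sulfur; one five-membered aromatic ring with 1 hetero atom, one six-membered aromatic ring of carbon only), on a nitrogen on an aromatic ring. For the measured compounds named here, the series offers no measured step that changes one place only, so the expectation in this assay is a judgement: a modest rise in the number, meaning a somewhat weaker inhibitor. The expected step is a 2.0-fold higher number from compound 1 to compound 3 (0.30 log units; within the scatter). Compound 3 is estimated at 1000 nM, with an expected range of 200 nM to 5000 nM.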

Compound 3, half-maximal inhibitory concentration: 15000 nM
Estimate against measurement, compound 3: 15-fold (1.18 log units) below, outside the stated range (above it).
By their numbers in this assay, from the lowest: compound 1; then compound 2; then compound 3.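

In this assay, the group on a nitrogen on an aromatic ring proves to be a sensitive point of the series: with the core of compound 1 held constant, replacing 1-benzothiophen-5-yl with the group carrying a five-membered non-aromatic ring gives a 30-fold higher number from compound 1 to compound 3 (1.48 log units; beyond the scatter). For the compounds shown here, this is the only one-place comparison, so it shows the size of this change but not which feature of the entering group matters. Nothing available accounts for the loss. Left open is how a plain phenyl or a phenyl carrying a piperazine would read on the same nitrogen. Compound 2 differs from compound 1 in more than one place, so it gives no separate reading of this position.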